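The compounds below may be only part of what the source reports. "The series", "measured", "known", "first", "only" and "open" are said of these compounds alone.

- Compound 1 `COc1ccccc1C(=O)/C=C/c1ccccc1`: 2230 nM
- Compound 2 `CCOc1ccccc1C(=O)/C=C/c1ccccc1`: 609 nM

In a functional assay for inhibition, with Homo sapiens as the target (a higher number here means a weaker inhibitor, a lower number a stronger inhibitor), compound 2 holds the lower of the two numbers, at 609 nM. Compound 3 `O=C(/C=C/c1ccccc1)c1ccccc1OCc1ccccc1` has not been measured. It differs from compound 2 by phenyl in place of methyl on a saturated chain carbon bound to an oxygen on an aromatic ring, with phenyl in place of methyl on a saturated chain carbon bound to an oxygen on an aromatic ring. For the measured compounds named here, only one measured step bears on this place, the modest 3.7-fold lower number from compound 1 to compound 2 (0.56 log units; beyond the scatter). That single step suggests a further modest drop, though the new group is much larger, so the expectation is loose. The expected change is a 1.5-fold lower number from compound 2 to compound 3 (0.18 log units; within the scatter). Compound 3 is estimated at 400 nM, within a range of 100 nM to 1800 nM.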

Compound 3, half-maximal inhibitory concentration: 2230 nM
Compound 3: the middle estimate sits 5.6-fold (0.75 log units) below what was measured, and the stated range ends below it.
By their numbers in this assay, from the lowest: compound 2; then compounds 1 and 3 (each within the scatter of the next).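

In this assay, the phenyl in place of methyl on the saturated chain carbon turns the earlier trend around, with a 3.7-fold higher number from compound 2 to compound 3 (0.56 log units; beyond the scatter), so enlarging the group at this position does not keep lowering the number. The same phenyl, compared with the smallest group, gives no change at the digits printed from compound 1 to compound 3 (within the scatter), which leaves compound 2 alone with the lowest number among the three. Nothing at hand accounts for this turn. The compounds shown leave open where between ethyl and benzyl the number turns upward, as a propyl chain might indicate, and whether an amine on the added phenyl would alter the reading.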